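Series notes: aryl group on ring nitrogen changed to pyrimidinyl

The source may hold more compounds than are shown below. What is called first, only, known or untested is meant among the compounds shown, and "the series" means these compounds.

Measured compounds:
- compound 1, `Nc1scc(CN2CCN(c3ccc(Cl)cc3)CC2)c1C(=O)c1ccc(Cl)cc1`; in an assay on CHO cells for displacement of a labelled ligand from adenosine receptor A1 (Homo sapiens) (a higher number here means weaker binding, a lower number tighter binding), compound 1 gives 1.1 nM
- compound 2, `Cc1ccc(N2CCN(Cc3csc(N)c3C(=O)c3ccc(Cl)cc3)CC2)cc1`; in this assay compound 2 gives 1 nM
- compound 3, `N#Cc1ccc(N2CCN(Cc3csc(N)c3C(=O)c3ccc(Cl)cc3)CC2)cc1`; in this assay compound 3 gives 1.1 nM

Compound 3 sits level with compound 1 and together they hold the highest of the three numbers, while compound 2 differs from both by an amount inside the usual scatter. All three measured steps change only the group on the aromatic ring attached to the ring nitrogen: a 1.1-fold lower number from compound 1 to compound 2 (0.04 log units; within the scatter), no change at the digits printed from compound 1 to compound 3 (within the scatter) and a 1.1-fold higher number from compound 2 to compound 3 (0.04 log units; within the scatter). None of them moves the number beyond the scatter.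

Compound 4, `Nc1scc(CN2CCN(c3ncccn3)CC2)c1C(=O)c1ccc(Cl)cc1`, goes a step further than these substituent swaps: pyrimidin-2-yl in place of 4-cyanophenyl on an amine nitrogen in a ring. Here the aromatic ring itself is exchanged rather than a group on it, so no measured step covers this change directly. Among the measured compounds shown here, the measured steps show only that varying the aryl group on this ring nitrogen has not shifted binding so far, and that is the sole basis for the expectation. The expected step for compound 4 is therefore a 2.3-fold higher number from compound 3 to compound 4 (0.36 log units; beyond the scatter), a small weakening at most, with wide uncertainty. Compound 4 is estimated at 2.5 nM in this assay, with a range from 0.6 nM to 10 nM.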

Compound 4, dissociation constant: 1.1 nM
Estimate against measurement, compound 4: 2.3-fold (0.36 log units) above; the range from low to high includes it.
By their numbers in this assay, from the lowest: compounds 2, 1, 3 and 4 (each within the scatter of the next).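

In this assay the exchange of the whole aromatic ring on the amine nitrogen in a ring stays within the scatter against all three earlier compounds, with no change at the digits printed from compound 3 to compound 4 (within the scatter), a 1.1-fold higher number from compound 2 to compound 4 (0.04 log units; within the scatter) and no change at the digits printed from compound 1 to compound 4 (within the scatter) as the measured steps. The earlier compounds shown here varied only a group on a six-membered aromatic ring of carbon only, whereas compound 4 shows that this position also accepts pyrimidin-2-yl, a six-membered aromatic ring with 2 hetero atoms, and no compound among the four goes against this flat picture. No available evidence explains why the number holds across this exchange.

From the compounds shown here alone, the four compounds all keep an aromatic ring on this nitrogen, so it remains open whether the flat picture survives a cyclohexyl group, a benzyl group or an acetyl group in its place. Going by these compounds, it also remains open whether a phenyl ring bearing a carboxylic acid or an amine, or a pyrimidin-2-yl ring carrying a further group such as methyl, would hold the number at this level on the same core.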